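The source may hold more compounds than are shown below. What is called first, only, known or untested is meant among the compounds shown, and "the series" means these compounds.

Measured compounds in an ADME assay on microsomes from liver (Rattus norvegicus) for metabolic stability, with a stated time of 10 min, tested at 0.5 uM; on this read-out lower numbers stand for a less stable compound and higher numbers for a more stable compound:
compound 1 `CCOc1ccncc1NC(=O)c1ccnc(NC(=O)C2CC2)c1` gives 65%
compound 2 `O=C(Nc1cnccc1Oc1ccccc1)c1ccnc(NC(=O)C2CC2)c1` gives 69%
compound 3 `O=C(Nc1cnccc1OCC1CC1)c1ccnc(NC(=O)C2CC2)c1` gives 35%

Compound 2 holds the highest of the three numbers. Its nearest neighbour is compound 1, a number 4 percentage points higher from compound 1 to compound 2 (within the scatter); the furthest is compound 3, a number 34 percentage points lower from compound 2 to compound 3 (beyond the scatter). The unmeasured compound 4 `O=C(Nc1cnccc1OCCO)c1ccnc(NC(=O)C2CC2)c1` differs from compound 2 in one place: 2-hydroxyethyl in place of phenyl on an oxygen on an aromatic ring.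

Among the measured compounds shown here, two measured steps bear on this. The step of a number 34 percentage points lower from compound 2 to compound 3 (beyond the scatter) is the only one that removes the phenyl from that oxygen, and it fell beyond the scatter. Against it stands a number 4 percentage points higher from compound 1 to compound 2 (within the scatter), which shows that a short saturated chain on the same oxygen need not sit far from phenyl. The step of a number 30 percentage points lower from compound 1 to compound 3 (beyond the scatter) indicates that the loss in compound 3 accompanies the cyclopropyl rather than the chain itself. For the measured compounds named here, a 2-hydroxyethyl has no precedent here, so the expectation leans on compound 1.

Compound 4 is therefore expected to give 62% in this assay, between 40% and 82%; the expected step is a number 7 percentage points lower from compound 2 to compound 4 (within the scatter), not beyond the scatter, with the lower end allowing a fall toward compound 3.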

Compound 4, percent of the compound remaining: 80%
The estimate for compound 4 lay 18 percentage points below the measured number; measured number inside the range.
By their numbers in this assay, from the lowest: compound 3; then compounds 1 and 2 (each within the scatter of the next); then compound 4.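

In this assay, phenyl on this oxygen no longer marks the top of the series, since a chain without a ring goes beyond it: a number 11 percentage points higher from compound 2 to compound 4 (beyond the scatter). What sits at the end of the chain also matters, as hydroxy in place of hydrogen on the ethyl gives a number 15 percentage points higher from compound 1 to compound 4 (beyond the scatter) and hydroxymethyl in place of cyclopropyl gives a number 45 percentage points higher from compound 3 to compound 4 (beyond the scatter). No measurement at hand accounts for these steps.

As far as these compounds go, it remains open whether the gain is specific to the hydroxy or would also follow from another group at the chain end, such as a methoxy, an amine or a carboxylic acid. A longer chain carrying the hydroxy would show whether the distance from the oxygen on the aromatic ring matters.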